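The compounds below may be only part of what the source reports. "The series", "measured", "known", "first", "only" and "open" are said of these compounds alone.

Measured compounds in an ADME assay on Vero cells (Chlorocebus sabaeus) for cytotoxicity, read by MTT assay, with a stated time of 72 h; a higher number here means a weaker inhibitor, a lower number a stronger inhibitor:
compound 1 `c1ccc(-c2nnc(-c3ccc(-n4cccc4)cc3)o2)cc1` gives 250000 nM;
compound 2 `Brc1ccccc1-c1nnc(-c2ccc(-n3cccc3)cc2)o1` gives 258000 nM.

Going by the values given here, compound 2 stands highest of the two numbers in this assay, with compound 1 nearest; the single measured step, a 1.0-fold higher number from compound 1 to compound 2 (0.01 log units; within the scatter), lies within the scatter. Compound 3 `O=[N+]([O-])c1ccccc1-c1nnc(-c2ccc(-n3cccc3)cc2)o1` differs from compound 2 by nitro in place of bromo on an aromatic carbon. Among the compounds with values here, no measured step concerns a nitro group; the only comparison available is the bromo-for-hydrogen step, which did not move the number beyond the scatter. The expected step for compound 3 is therefore a 1.0-fold lower number from compound 2 to compound 3 (0.01 log units; within the scatter). Compound 3 is estimated at 250000 nM, with a range from 110000 nM to 560000 nM.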

Compound 3, half-maximal inhibitory concentration: 266000 nM
Estimate against measurement, compound 3: 1.1-fold (0.03 log units) below; low and high end bracket the measured number.
By their numbers in this assay, from the lowest: compounds 1, 2 and 3 (each within the scatter of the next).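

In this assay, nitro in place of bromo on this aromatic carbon, ortho to a large group, gives (a 1.0-fold higher number from compound 2 to compound 3 (0.01 log units; within the scatter)), and nitro in place of hydrogen gives (a 1.1-fold higher number from compound 1 to compound 3 (0.03 log units; within the scatter)). A second, larger group with hydrogen-bond acceptors thus also leaves the number within the scatter, so hydrogen, bromo and nitro read alike at this position. Nothing at hand bears on the reason for this. Still open, going by these compounds, is whether an amine or a carboxylic acid here would read alike, and whether a change elsewhere in the shared core would move the number at all.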